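The source may hold more compounds than are shown below. What is called first, only, known or untested is meant among the compounds shown, and "the series" means these compounds.

Measured in an assay for inhibition of NADPH oxidase 4 (Homo sapiens), read by chemiluminescence; a lower number here means a stronger inhibitor, a higher number a weaker inhibitor:
- compound 1 `CN1C(=S)N(C2CCCCC2)C(=O)/C1=C/c1ccc(O)cc1O`: 37600 nM
- compound 2 `Cc1ccc(N2C(=O)/C(=C/c3ccc(O)cc3O)N(C)C2=S)cc1`: 34600 nM

Compound 2 and compound 1 share one core and differ only in the group on an amide-type nitrogen in a ring, a 4-methylphenyl in compound 2 where compound 1 carries a cyclohexyl. This change gives a 1.1-fold lower number from compound 1 to compound 2 (0.04 log units; within the scatter), so the two numbers cannot be told apart, and neither compound can be called the stronger inhibitor.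

Compound 3 `CCc1ccc(N2C(=O)/C(=C/c3ccc(O)cc3O)N(C)C2=S)cc1` is the next step from compound 2: methyl in place of hydrogen on a saturated chain carbon bound to an aromatic carbon. For the measured compounds named here, the only measured step, from compound 1 to compound 2, also alters the group on that ring nitrogen, and it stayed within the scatter. The change to compound 3 is smaller still, adding a single carbon to the 4-methylphenyl. Nothing measured here points to a shift in either direction, so for compound 3 a step of a 1.0-fold lower number from compound 2 to compound 3 (0.02 log units; within the scatter) is expected, that is, nothing beyond the scatter. Compound 3 is therefore estimated at 33000 nM, with a range from 15000 nM to 72000 nM.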

Compound 3, inhibition constant: 2390 nM
The estimate for compound 3 lay 14-fold (1.14 log units) above the measured number, and the stated range ends above it.
By their numbers in this assay, from the lowest: compound 3; then compounds 2 and 1 (each within the scatter of the next).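

In this assay, the group on the ring nitrogen turns out to matter after all. Adding one methyl on a saturated chain carbon bound to an aromatic carbon, which turns 4-methylphenyl into 4-ethylphenyl, gives a 14-fold lower number from compound 2 to compound 3 (1.16 log units; beyond the scatter), whereas exchanging cyclohexyl for 4-methylphenyl had given only a 1.1-fold lower number from compound 1 to compound 2 (0.04 log units; within the scatter). Exchanging cyclohexyl for 4-ethylphenyl gives a 16-fold lower number from compound 1 to compound 3 (1.20 log units; beyond the scatter), so among these three compounds the large drop appears only once the ethyl group is present, and a change of a single carbon can separate compounds that otherwise look almost identical. No measurement available here explains why so small a change has so large a result.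

The compounds shown leave open whether the number keeps falling with a longer chain, such as propyl or butyl, or whether the drop belongs to the ethyl group alone. As far as these compounds go, it also remains open whether a branched isopropyl group or a methoxy group in the same place would keep the number as low as that of compound 3.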